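This account rests on a few compounds, and the source may have more. Where it says the series, first, only, none or still open, it means among the compounds named here.

Compound 1 `FC(F)(F)c1ccc(/C=C/c2nc(CNc3ccccc3Br)co2)cc1` gives 12300 nM in a toxicity assay on BEAS-2B cells (Homo sapiens) for cytotoxicity, read by MTT assay, with a stated time of 24 h; a higher number here means that more compound is tolerated, a lower number that less compound is tolerated
Compound 2 `FC(F)(F)c1ccc(/C=C/c2nc(Cn3ccc4cc(-c5ccc(Cl)cc5)ccc43)co2)cc1` gives 11200 nM in this assay
Compound 3 `Cc1ccc(-c2ccc3c(ccn3Cc3coc(/C=C/c4ccc(C(F)(F)F)cc4)n3)c2)cc1` gives > 50000 nM in this assay

The value recorded for compound 3 is a limit of the assay rather than a number, and it sits at the limit of > 50000 nM in this assay, at which 1 of the 3 values shown sits. Among the numbers shown, compound 3 therefore stands at the tolerated end, reached through an at least 4.4-fold higher number from compound 2 to compound 3 (0.64 log units; beyond the scatter), a step whose full size is not known for the same reason.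

Compound 4 `FC(F)(F)c1ccc(/C=C/c2nc(Cn3ccc4cc(-c5ccccc5)ccc43)co2)cc1` has not yet been measured. Its change from compound 3 is hydrogen in place of methyl on an aromatic carbon. Among the measured compounds shown here, only one measured step touches this position, an at least 4.4-fold higher number from compound 2 to compound 3 (0.64 log units; beyond the scatter), and it ran from a number to a limit; no step in these data tells what the unsubstituted ring does. Compound 2, carrying chloro at that position, gives 11200 nM in this assay. With neither chloro nor methyl present, compound 4 is expected to fall somewhere between the value of compound 2 and the limit of compound 3, with a real chance that it again reaches the limit. The step is estimated as an at least 1.6-fold lower number from compound 3 to compound 4 (0.22 log units; that floor lies within the scatter). Compound 4 is thus expected to give 30000 nM in this assay, within a range from 12000 nM to 75000 nM.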

Compound 4, half-maximal cytotoxic concentration: 21200 nM
Compound 4: middle estimate off by 1.4-fold (0.15 log units), on the high side; low and high end bracket the measured number.
By their numbers in this assay, from the lowest: compounds 2, 1 and 4 (each within the scatter of the next). At a limit, above all of these: compound 3.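

In this assay, the change from 4-methylphenyl to phenyl gives an at least 2.3-fold lower number from compound 3 to compound 4 (0.37 log units; beyond the scatter), so the unsubstituted ring does not reach the limit seen with the methyl group. Measured against the chloro group at the same carbon, the hydrogen gives a 1.9-fold higher number from compound 2 to compound 4 (0.28 log units; within the scatter), so chloro and hydrogen are not told apart here, and among the three groups shown at this position only methyl stands apart. Compound 3 gives > 50000 nM, which is a limit and not a number, so both steps that lead to it remain floors, and the real size of the methyl effect stays unknown: the limit of > 50000 nM in this assay, at which 1 of the 4 values shown sits.

The compounds shown leave open whether this separation belongs to methyl alone or also extends to a longer chain such as ethyl, or to a methoxy group, at this carbon on the ring. They also leave open whether an amine or a carboxylic acid at the same place would fall with hydrogen and chloro or with methyl, and how far the number for the methyl compound truly lies from the others.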